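Trading thiophen-2-yl for 1-benzofuran-2-yl at the assay limit

The source may hold more compounds than are shown below. What is called first, only, known or untested is meant among the compounds shown, and "the series" means these compounds.

In a functional assay on K562 cells (Homo sapiens), read by MTT assay, with a stated time of 72 h (a higher number here means a weaker inhibitor, a lower number a stronger inhibitor), compound 3 (`COc1nc(N)nc2c1c(-c1cccs1)cn2[C@@H]1O[C@H](CO)[C@@H](O)[C@H]1O`) gives only a limit, > 20000 nM, and no exact number. Compound 2 (`COc1nc(N)nc2c1c(-c1ccoc1)cn2[C@@H]1O[C@H](CO)[C@@H](O)[C@H]1O`) also gives only a limit, > 20000 nM. For the measured compounds named here, the single measured step between compounds that differ in one place is a step that the two limits leave unreadable from compound 2 to compound 3, so it offers no size to carry forward.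

Compound 4 (`COc1nc(N)nc2c1c(-c1cc3ccccc3o1)cn2[C@@H]1O[C@H](CO)[C@@H](O)[C@H]1O`) keeps the core of compound 3 and changes one group on an aromatic carbon of a five-membered aromatic ring with 1 nitrogen: 1-benzofuran-2-yl in place of thiophen-2-yl on an aromatic carbon. The best remaining clue comes from compound 1 (`Nc1nc(N)c2c(-c3cc4ccccc4o3)cn([C@@H]3O[C@H](CO)[C@@H](O)[C@H]3O)c2n1`), which carries the same 1-benzofuran-2-yl group on a different core. In this assay, compound 1 gives a true number, 18600 nM. That value hints that the larger group may bring compound 4 within measurable range, though the change of core makes this a weak guide.

A small gain in strength is therefore expected, and it may not exceed the usual scatter: the estimated change is an at least 1.2-fold lower number from compound 3 to compound 4 (0.09 log units; that floor lies within the scatter). For compound 4, the expected value is 16000 nM, with an estimated range from 6000 nM to 30000 nM.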

Compound 4, half-maximal inhibitory concentration: 14600 nM
The estimate for compound 4 lay 1.1-fold (0.04 log units) above the measured number, and the stated range covers the measured number.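

With 1-benzofuran-2-yl on this aromatic carbon, the methoxy core gives a true number in this assay, where furan-3-yl and thiophen-2-yl gave only limits, and the result is an at least 1.3-fold lower number from compound 3 to compound 4 (0.13 log units; that floor lies within the scatter) and an at least 1.3-fold lower number from compound 2 to compound 4 (0.13 log units; that floor lies within the scatter). These two steps are floors rather than full sizes because the starting compounds sit at the limit of the assay: the limit of > 20000 nM in this assay, at which 2 of the 4 values shown sit. With 1-benzofuran-2-yl held fixed, the other change, methoxy in place of amino on an aromatic carbon, gives a 1.3-fold lower number from compound 1 to compound 4 (0.11 log units; within the scatter), so in this pair that swap cannot be told apart from the noise of the measurement.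

The compounds shown leave open whether the step at this carbon goes with the added six-membered aromatic ring or with oxygen in place of sulfur in the five-membered ring, a question that furan-2-yl or 1-benzothiophen-2-yl on the same core would separate. Also open, on these data alone, is how a phenyl group or a short chain ending in an amine would behave at this carbon, and whether any group here can move the number beyond the scatter.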